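A few compounds are considered here, and "the series" means these few. Any claim that something is new, unique, unknown or untested is made for them only; others in the source may bear on it.

Compound 1 `Cc1ccc(S(=O)(=O)/N=C(/CCNC2=CC(=O)c3ccccc3C2=O)Nc2ccc(F)cc2)cc1` gives 4260 nM in a functional assay on MCF7 cells (Homo sapiens) for cytotoxicity, read by MTT assay, with a stated time of 48 h; a lower number here means a stronger inhibitor, a higher number a weaker inhibitor.
Compound 2 `COc1ccc(N/C(CCNC2=CC(=O)c3ccccc3C2=O)=N\S(=O)(=O)c2ccc(C)cc2)cc1OC` gives 12300 nM in this assay.
Compound 3 `Cc1ccc(S(=O)(=O)/N=C(/CCNC2=CC(=O)c3ccccc3C2=O)Nc2ccc(Cl)cc2Cl)cc1` gives 17000 nM in this assay.

Compound 1 holds the lowest number of the three; the nearest is compound 2, with a 2.9-fold higher number from compound 1 to compound 2 (0.46 log units; beyond the scatter), and the furthest is compound 3, with a 4.0-fold higher number from compound 1 to compound 3 (0.60 log units; beyond the scatter). Compounds 2 and 3 stand close to each other, with a 1.4-fold higher number from compound 2 to compound 3 (0.14 log units; within the scatter).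

Compound 4 `Cc1ccc(S(=O)(=O)/N=C(/CCNC2=CC(=O)c3ccccc3C2=O)NCc2ccccc2)cc1` is not yet measured. It differs from compound 1 in one place: benzyl in place of 4-fluorophenyl on an amine nitrogen.

Both measured steps away from compound 1 exchange the same 4-fluorophenyl group on the amine nitrogen, and both raise the number in this assay by a modest amount beyond the scatter. Among the compounds with values here, neither introduces benzyl, so the step to compound 4 has no direct counterpart, but the available steps point the same way. Compound 4 is therefore expected to show a modest rise, a 1.9-fold higher number from compound 1 to compound 4 (0.27 log units; within the scatter), though a step within the scatter cannot be ruled out. Compound 4 is estimated at 8000 nM, with a range from 3000 nM to 25000 nM.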

Compound 4, half-maximal inhibitory concentration: 3630 nM
For compound 4 the middle estimate is 2.2-fold (0.34 log units) above the measured one; low and high end bracket the measured number.
By their numbers in this assay, from the lowest: compounds 4 and 1 (each within the scatter of the next); then compounds 2 and 3 (each within the scatter of the next).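

In this assay, within the data shown here, benzyl is the first group at this amine nitrogen that keeps compound 4 within the scatter of compound 1 (a 1.2-fold lower number from compound 1 to compound 4 (0.07 log units; within the scatter)), whereas both earlier exchanges of the 4-fluorophenyl group went beyond it. Benzyl also separates compound 4 from the two other substituted compounds (a 4.7-fold lower number from compound 3 to compound 4 (0.67 log units; beyond the scatter); a 3.4-fold lower number from compound 2 to compound 4 (0.53 log units; beyond the scatter)), so among these four compounds a ring attached to this nitrogen through a carbon does as well as the 4-fluorophenyl ring attached directly. No measured evidence bears on the reason for these steps.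

This exchange adds a carbon and removes the fluorine at once, so the two changes cannot be told apart here. A 4-fluorobenzyl group or a plain phenyl group would separate them, and a 2-phenylethyl group would show whether a longer chain on this nitrogen keeps the number.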